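The source may report more compounds than this note shows. Statements on the series, on what has been measured and on what is new or still open speak of the compounds shown alone.

Measured so far in a functional assay on JeKo-1 cells (Homo sapiens) for inhibition, read by luminescence and CellTiter-Glo, with a stated time of 72 h; on this read-out higher numbers stand for weaker inhibition and lower numbers for stronger inhibition:
compound 1 `C=CC(=O)Nc1ccc(Cn2nc(-c3ccc(Oc4ccccc4)cc3)cc2C(=O)O)cc1`: compound 1 gives > 60000 nM, which is a limit of the assay rather than a number.
compound 2 `C/C=C/C(=O)Nc1ccc(Cn2nc(-c3ccc(Oc4ccccc4)cc3)cc2C(=O)OCC)cc1`: compound 2 gives 52500 nM.
compound 3 `O=C(CCl)Nc1ccc(Cn2nc(-c3ccc(Oc4ccccc4)cc3)cc2C(=O)O)cc1`: compound 3 gives 2500 nM.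

Compound 3 stands lowest of the two numbers shown; its nearest neighbour is compound 2, and that gap lies beyond the scatter. Within the data shown here, the only step between compounds differing in one place is an at least 24-fold lower number from compound 1 to compound 3 (1.38 log units; beyond the scatter), a large move to a lower number; its size is bounded on one side by the limit of > 60000 nM in this assay, at which 1 of the 3 values shown sits, so the true step may be larger still.

Compound 4 `C/C=C/C(=O)Nc1ccc(Cn2nc(-c3ccc(Oc4ccccc4)cc3)cc2C(=O)O)cc1` is the next compound to be measured. Relative to compound 3 the change is prop-1-en-1-yl in place of chloromethyl on a carbonyl carbon. This undoes, in a close variant, the change that gave the large step from compound 1 to compound 3, and compound 2, which carries the same prop-1-en-1-yl group on its carbonyl carbon, sits weak as well. A large step to a higher number in this assay is therefore expected from compound 3 to compound 4, a 20-fold higher number from compound 3 to compound 4 (1.30 log units; beyond the scatter), with a real chance that only a limit is returned. Compound 4 is estimated at 50000 nM, in the range 15000 nM to 150000 nM.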

Compound 4, half-maximal inhibitory concentration: > 60000 nM
Compound 4 gave a limit, no number; the forecaster's own chance of this, stated with the estimate: 40%; middle value at least 1.2-fold (0.07 log units) away from the limit.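

In this assay chloromethyl now stands against a second alkene group on the same carbonyl carbon: prop-1-en-1-yl in its place gives an at least 24-fold higher number from compound 3 to compound 4 (1.38 log units; beyond the scatter), so the advantage of compound 3 does not rest on the comparison with vinyl alone. With prop-1-en-1-yl held constant, hydrogen in place of ethyl on an oxygen next to a carbonyl group gives an at least 1.1-fold higher number from compound 2 to compound 4 (0.05 log units; that floor lies within the scatter), and this floor shows no separation between the ethyl ester and the free carboxylic acid. Compound 4 returns a limit and not a number, as does compound 1, so the step between them cannot be read and the vinyl and prop-1-en-1-yl groups cannot be ranked: the limit of > 60000 nM in this assay, at which 2 of the 4 values shown sit.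

Chloromethyl is the only group on this carbonyl carbon that gives a value well clear of that limit, and it remains open whether a bromomethyl or a plain methyl group there would keep or lose that gain. It is also open how the ethyl ester would read when paired with chloromethyl, as the ester comparison shown rests on prop-1-en-1-yl alone.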